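The source may report more compounds than this note shows. Statements on the series, on what has been measured and on what is new or still open speak of the compounds shown alone.

Working notes on the series. Three compounds sharing one core carry a benzylamide whose aryl fluorination varies. Compound 1 `CC(C)c1c(C(=O)NCc2ccccc2)nc(-c2ccc(F)cc2)n1CC[C@@H](O)C[C@@H](O)CC(=O)O` gives 3030 nM in a functional assay on L6 cells (Rattus norvegicus) for inhibition, read by scintillation counting, with a stated time of 3 h; a lower number here means a stronger inhibitor, a higher number a weaker inhibitor. Compound 2 `O=C(O)C[C@H](O)C[C@H](O)CCn1c(-c2ccc(F)cc2)nc(C(=O)NCc2ccc(F)c(F)c2)c1C1CC1`, with a 3,4-difluorobenzyl group, gives 2780 nM in this assay, which is the second highest of the three numbers; its nearest neighbour is compound 1, and the furthest is compound 3 `O=C(O)C[C@H](O)C[C@H](O)CCn1c(-c2ccc(F)cc2)nc(C(=O)NCc2ccc(F)cc2)c1C1CC1`, which gives 1620 nM in this assay. Within the data shown here, the one step measured within the set, a 1.7-fold lower number from compound 2 to compound 3 (0.23 log units; within the scatter), is hydrogen in place of fluoro on an aromatic carbon of the same benzyl ring, and it stays within the scatter.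

Compound 4 `O=C(O)C[C@H](O)C[C@H](O)CCn1c(-c2ccc(F)cc2)nc(C(=O)NCc2cccc(F)c2)c1C1CC1` is not yet measured. It differs from compound 2 by hydrogen in place of fluoro on an aromatic carbon, which cut one bond further out reads 3,4-difluorobenzyl to 3-fluorobenzyl. The step from compound 2 to compound 3 is the only one that bears on it, since it removes a fluoro from the same ring, and it produced no movement beyond the scatter. The expectation for compound 4 is therefore a step of a 1.1-fold lower number from compound 2 to compound 4 (0.05 log units; within the scatter), that is, no change beyond the scatter. The estimate for compound 4 in this assay is 2500 nM, with a range from 1200 nM to 5200 nM.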

Compound 4, half-maximal inhibitory concentration: 444 nM
The estimate for compound 4 lay 5.6-fold (0.75 log units) above the measured number; the measured number lies below the stated range.
By their numbers in this assay, from the lowest: compound 4; then compounds 3, 2 and 1 (each within the scatter of the next).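

In this assay the same kind of change, hydrogen in place of fluoro on the benzyl ring, gives a 6.3-fold lower number from compound 2 to compound 4 (0.80 log units; beyond the scatter) when the fluoro that leaves is para to a large group, against a 1.7-fold lower number from compound 2 to compound 3 (0.23 log units; within the scatter) when the other fluoro leaves, so the two fluoro places of the 3,4-difluorobenzyl group do not count alike. Among these compounds, with a single fluoro on the ring, its place alone separates the two compounds: 3-fluorophenyl in place of 4-fluorophenyl gives a 3.6-fold lower number from compound 3 to compound 4 (0.56 log units; beyond the scatter) and this step too lies beyond the scatter, which the earlier compounds could not show. No measurement at hand bears on why the place of the fluoro matters.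

Still open, on these data alone, is whether the effect belongs to fluoro itself or would carry over to a chloro or methoxy group on the same ring carbon of the benzyl group. Also open, as far as these compounds go, is how the plain benzyl amide compares on the core of compound 4, since compound 1 carries that amide but differs from compound 4 in more than one place and gives no clean reading.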